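Aryl exchange from compound 2 to compound 3

The source may report more compounds than this note shows. Statements on the series, on what has been measured and on what is new or still open speak of the compounds shown alone.

In an ADME assay on MT4 cells (Homo sapiens) for cytotoxicity (on this read-out higher numbers stand for lower toxicity in this test and lower numbers for higher toxicity in this test), compound 1 (`COc1ccc(-c2nnsc2SCC(=O)Nc2ccc(C)cc2Br)cc1`) gives 249000 nM. Compound 2 (`COc1ccc(-c2nnsc2SCC(=O)Nc2ccccc2Br)cc1`) gives > 286000 nM in this assay, and this is a limit of the assay, not a number. Compound 3 (`O=C(CSc1snnc1-c1ccc(F)cc1F)Nc1ccccc1Br`) is not yet measured. It carries 2,4-difluorophenyl in place of 4-methoxyphenyl on an aromatic carbon.

Going by the values given here, the only measured step, an at least 1.1-fold higher number from compound 1 to compound 2 (0.06 log units; that floor lies within the scatter), is hydrogen in place of methyl on an aromatic carbon, so it does not test the group exchanged here. Among the compounds with values here, it offers no precedent for a large move, and the data hold no measured change of this group. No shift beyond the scatter is therefore expected in this assay, although the limit on compound 2 leaves the true size open.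

The expected change is an at least 1.1-fold lower number from compound 2 to compound 3 (0.05 log units; that floor lies within the scatter). For compound 3, the estimated value is 250000 nM, with an expected range from 110000 nM to 320000 nM.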

Compound 3, half-maximal cytotoxic concentration: 144000 nM
Estimate against measurement, compound 3: 1.7-fold (0.24 log units) above, within the range that was stated.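

Going by these compounds alone, the step of an at least 1.9-fold lower number from compound 2 to compound 3 (0.29 log units; that floor lies within the scatter) is the first reading of any exchange at this aryl position in this assay, since the earlier step concerned only a methyl group on the other aromatic ring. Its printed floor lies within the scatter, so the exchange of 4-methoxyphenyl for 2,4-difluorophenyl is not shown to lower the number beyond the scatter, though a larger drop is not excluded. The value for compound 2 is a limit of the assay and not a number, so only that floor can be read: the limit of > 286000 nM in this assay, at which 1 of the 3 values shown sits.

From the compounds shown here alone, the true size of this step remains open, and so does whether the two fluorines or the loss of the methoxy group carries any change. Plain phenyl or 4-fluorophenyl in this place would separate those two parts of the exchange.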